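From Ethyl to Cyclohexyl: Expected Cytotoxicity of Compound 4

The source may hold more compounds than are shown below. What is called first, only, known or untested is meant among the compounds shown, and "the series" means these compounds.

Measured in an ADME assay on MDCK cells (Canis lupus familiaris) for cytotoxicity, read by microscopy, with a stated time of 48 h; on this read-out higher numbers stand for lower toxicity in this test and lower numbers for higher toxicity in this test:
Compound 1 `CCc1csc(CN[C@@H]2C[C@H]3C[C@@H]([C@H]2C)C3(C)C)c1` gives 25000 nM.
Compound 2 `C[C@H]1[C@H](NCc2ccc(Br)s2)C[C@H]2C[C@@H]1C2(C)C` gives 43000 nM.
Compound 3 `C[C@H]1[C@H](NCc2sccc2-c2ccccc2)C[C@H]2C[C@@H]1C2(C)C` gives 12500 nM.

Among these three numbers, compound 1 holds the second highest; its value sits within the scatter of both compound 2 and compound 3, so none of the three can be called more or less toxic than another on this evidence. Compound 4 `C[C@H]1[C@H](NCc2cc(C3CCCCC3)cs2)C[C@H]2C[C@@H]1C2(C)C` is not yet measured. It differs from compound 1 in one place: cyclohexyl in place of ethyl on an aromatic carbon. Going by the values given here, no step between two measured compounds mirrors this change, so the expectation rests on the spread of the three values alone. Compound 4 is expected to give a somewhat lower number than compound 1, a step of a 1.8-fold lower number from compound 1 to compound 4 (0.25 log units; within the scatter) that stays within the scatter. The estimate for compound 4 in this assay is 14000 nM, with a range from 6000 nM to 35000 nM.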

Compound 4, minimum cytotoxic concentration: 780 nM
Compound 4: middle estimate off by 18-fold (1.25 log units), on the high side, and the stated range ends above it.
By their numbers in this assay, from the lowest: compound 4; then compounds 3, 1 and 2 (each within the scatter of the next, the first and the last beyond it).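

Replacing ethyl with cyclohexyl on this aromatic carbon, two ring bonds from the ring sulfur, gives a 32-fold lower number from compound 1 to compound 4 (1.51 log units; beyond the scatter) in this assay, which means higher toxicity in this test. The earlier compounds shown here showed no difference beyond the scatter, whereas this single change produces a large one. No available measurement explains the change.

Going by these compounds, it remains open whether a propyl or cyclopropyl group at this position would give a number closer to that of compound 1 or compound 4. A piperidine ring there is equally untested by these compounds.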